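The source may hold more compounds than are shown below. What is called first, only, known or untested is meant among the compounds shown, and "the series" means these compounds.

Measured compounds:
Compound 1 `CC1=CC[C@H](C(C)C)c2cc(C)c(OC(=O)c3ccc(C(F)(F)F)cc3)cc21` gives 12.3% in a functional assay on PC-3 cells (Homo sapiens) for antiproliferative activity, read by sulforhodamine B assay, with a stated time of 48 h, tested at 50 uM; on this read-out lower numbers stand for less inhibition and higher numbers for more inhibition at the one concentration tested (going by the name of the read-out).
Compound 2 `CC1=CC[C@H](C(C)C)c2cc(C)c(OC(=O)c3ccc(Cl)cc3)cc21` gives 34.1% in this assay.
Compound 3 `CC1=CC[C@H](C(C)C)c2cc(C)c(OC(=O)c3cccc(Cl)c3)cc21` gives 23.4% in this assay.

Compound 4 `CC1=CC[C@H](C(C)C)c2cc(C)c(OC(=O)c3cccc(C(F)(F)F)c3)cc21` is not yet measured. It differs from compound 3 by trifluoromethyl in place of chloro on an aromatic carbon. The same kind of change is already measured once, from compound 2 to compound 1, where the difference is trifluoromethyl in place of chloro on an aromatic carbon; there the trifluoromethyl stands para to a large group, whereas in compound 4 it stands meta to a large group. That measured step was a number 21.8 percentage points lower from compound 2 to compound 1 (beyond the scatter). Compound 3 itself differs from compound 2 by 3-chlorophenyl in place of 4-chlorophenyl on a carbonyl carbon, a step of a number 10.7 percentage points lower from compound 2 to compound 3 (beyond the scatter).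

Because compound 2 to compound 1 showed a number 21.8 percentage points lower from compound 2 to compound 1 (beyond the scatter), a drop of comparable size, limited by the low starting point of compound 3, is expected for compound 4, an estimated step of a number 15.4 percentage points lower from compound 3 to compound 4 (beyond the scatter). Compound 4 is thus expected to give about 8% in this assay, with the estimate ranging from 0% to 20%.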

Compound 4, a percentage reported as inhibition, at one concentration (the size of the read-out at that concentration, not a potency): 25.4%
The estimate for compound 4 lay 17.4 percentage points below the measured number, outside the stated range (above it).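

In this assay, trifluoromethyl in place of chloro gives a number 2 percentage points higher from compound 3 to compound 4 (within the scatter) and so, meta to a large group, leaves the read-out unchanged within the scatter. The change therefore does not carry over with a single size from one core to the other in this series: the same change on two cores in this assay, a number 21.8 percentage points lower (beyond the scatter) from compound 2 to compound 1 and a number 2 percentage points higher (within the scatter) from compound 3 to compound 4, 23.8 percentage points apart, beyond the scatter of two such steps. These two pairs show that the earlier step cannot simply be transferred, but they do not show why the steps differ or how the change would behave at any other place.

The compounds shown leave open how an amine or a carboxylic acid in place of chloro or trifluoromethyl would read in this assay. They also leave open whether the two steps would stay apart with an amide in place of the ester.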